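The source may hold more compounds than are shown below. What is called first, only, known or untested is meant among the compounds shown, and "the series" means these compounds.

Measured compounds:
compound 1, `COc1cccc(N2C(=O)COc3ccc(-c4cccc(NS(=O)(=O)c5ccc(F)cc5)c4)cc32)c1`, gives > 40000 nM in a functional assay on HCT-116 cells (Homo sapiens) for antiproliferative activity, read by MTT assay, with a stated time of 72 h; a higher number here means a weaker inhibitor, a lower number a stronger inhibitor.
compound 2, `Cc1ccc(N2C(=O)COc3ccc(-c4cnc(Cl)c(NS(=O)(=O)c5ccc(F)cc5)c4)cc32)cc1`, gives 34300 nM in this assay.

The value for compound 1 is a limit of the assay rather than a number, so on the numbers shown compound 1 stands at the limit, as the limit of > 40000 nM in this assay, at which 1 of the 2 values shown sits, records. Compound 2, in turn, gives a number within the measured range.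

Compound 3, `Cc1ccc(N2C(=O)COc3ccc(-c4cccc(NS(=O)(=O)c5ccc(F)cc5)c4)cc32)cc1`, has not yet been measured. It differs from compound 1 in a single place: 4-methylphenyl in place of 3-methoxyphenyl on an amide-type nitrogen in a ring. Going by the values given here, no step between two measured compounds covers this change on its own, so nothing measured tells how large it should be. In this assay a step of no more than the usual scatter is expected, in no clear direction: compound 3 keeps everything else of compound 1, which sits at the limit (the limit of > 40000 nM in this assay, at which 1 of the 2 values shown sits). Compound 3 is therefore expected to give about 40000 nM, in a range from 15000 nM to 100000 nM. This expectation corresponds to a step of a number no higher from compound 1 to compound 3 (the limit leaves the size open).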

Compound 3, half-maximal inhibitory concentration: 35600 nM
The estimate for compound 3 lay 1.1-fold (0.05 log units) above the measured number; the range from low to high includes it.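

In this assay compound 1 gives > 40000 nM, which is a limit of the assay and not a number. With 4-methylphenyl in place of 3-methoxyphenyl on the amide-type nitrogen in a ring, the data show an at least 1.1-fold lower number from compound 1 to compound 3 (0.05 log units; that floor lies within the scatter), so this change yields a real number on the shared core, yet one that stays close to that limit and gives no sign of strong antiproliferative activity. The true size of the step remains unknown, because one end of it is only a limit: the limit of > 40000 nM in this assay, at which 1 of the 3 values shown sits.

The change also alters two things at once, the group on the phenyl ring and its place there, and the compounds shown cannot separate them, since they include neither 3-methylphenyl nor 4-methoxyphenyl on this nitrogen. Also open, on these data alone, is how a phenyl ring bearing an amine or a carboxylic acid, or a longer chain on this nitrogen in place of the phenyl ring, would read in this assay.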